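This account rests on a few compounds, and the source may have more. Where it says the series, first, only, none or still open, it means among the compounds named here.

Working notes on the series. Among the compounds with values here, compound 1 `CN(Cc1ccc(C(=O)O)cc1)c1ccc(OCc2c(-c3c(Cl)cccc3Cl)noc2C2CC2)nc1C(F)(F)F` gives 12 nM in an assay on isolated protein for agonist activity at Bile acid receptor (Homo sapiens), read by FRET (on this read-out lower numbers stand for an effect already at smaller amounts and higher numbers for an effect only at larger amounts of compound), the lowest of the three numbers so far; compound 2 `CN(Cc1ccc(C(=O)NCCS(=O)(=O)O)cc1)c1ccc(OCc2c(-c3c(Cl)cccc3Cl)noc2C2CC2)nc1C(F)(F)F` sits within the scatter of it at 14 nM, while compound 3 `CCN(Cc1ccc(C(=O)O)cc1)c1ccc(OCc2c(-c3c(Cl)cccc3Cl)noc2C2CC2)nc1C(F)(F)F` lies furthest away at 194 nM. The two measured steps read: a 1.2-fold higher number from compound 1 to compound 2 (0.07 log units; within the scatter) and a 16-fold higher number from compound 1 to compound 3 (1.21 log units; beyond the scatter). Compound 4 `O=C(O)c1cccc(OCc2ccc(OCc3c(-c4c(Cl)cccc4Cl)noc3C3CC3)nc2C(F)(F)F)c1` is not yet measured. It differs from compound 1 in one place: (3-carboxyphenoxy)methyl in place of (4-carboxybenzyl)(methyl)amino on an aromatic carbon. Neither measured step probes this exact change. The step from compound 1 to compound 2 alters only the hydroxy on the carbonyl carbon and leaves the number where it was, whereas the step from compound 1 to compound 3, a single methyl on the saturated chain carbon bound to a nitrogen on an aromatic ring, costs a large amount. The change to compound 4 reworks that same part of the molecule far more deeply, so a loss beyond the scatter is expected, the step of a 10-fold higher number from compound 1 to compound 4 (1.00 log units; beyond the scatter) being the estimate. Compound 4 is therefore expected at 120 nM, with a range from 25 nM to 700 nM.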

Compound 4, half-maximal effective concentration: 43 nM
The estimate for compound 4 lay 2.8-fold (0.45 log units) above the measured number; measured number inside the range.
By their numbers in this assay, from the lowest: compounds 1 and 2 (each within the scatter of the next); then compound 4; then compound 3.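

In this assay the exchange of (4-carboxybenzyl)(methyl)amino for (3-carboxyphenoxy)methyl gives a 3.6-fold higher number from compound 1 to compound 4 (0.55 log units; beyond the scatter) and this loss, though beyond the scatter, is only modest for a change of the whole group. The aromatic carbon ortho to a trifluoromethyl group therefore keeps a number in the nanomolar range without the amino nitrogen of compound 1, with the carboxylic acid carried on a phenoxymethyl group instead. No measurement available here bears on why this exchange costs so little. The compounds shown do not separate the effect of the new connecting atoms from that of moving the carboxylic acid, which a (4-carboxyphenoxy)methyl group at the same carbon would address. Also open, as far as these compounds go, is whether (2-sulfoethyl)amino on the carbonyl carbon of compound 4, or a primary amide there, would leave its number unchanged.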